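A few compounds are considered here, and "the series" means these few. Any claim that something is new, unique, unknown or untested is made for them only; others in the source may bear on it.

Measured compounds in a toxicity assay on HepG2 2.2.15 cells (Homo sapiens) for cytotoxicity, read by CellTiter-Glo; a higher number here means that more compound is tolerated, a lower number that less compound is tolerated:
- Compound 1 `O=C1CC(c2cnco2)CN1c1cnn2c1CN(C(=O)Nc1cc(F)c(F)c(F)c1)C(C1CC1)C2` gives 139000 nM.
- Compound 2 `C[C@H]1Cn2ncc(N3CC(c4ccccc4)CC3=O)c2CN1C(=S)Nc1cc(F)c(F)c(F)c1` reaches only the assay limit of > 2000 nM.
- Compound 3 `C[C@H]1Cn2ncc(N3CC(c4ccccc4)CC3=O)c2CN1C(=O)NCc1cc(F)c(F)c(F)c1` likewise reaches only the assay limit of > 2000 nM.

Going by the values given here, compound 1 stands as the only compound of the three with a number in this assay; for compounds 2 and 3 the assay reports a limit, and (the limit of > 2000 nM in this assay, at which 2 of the 3 values shown sit). Among the compounds with values here, the value of compound 1 is therefore the sole anchor for the step ahead.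

Compound 4 `O=C(Nc1cc(F)c(F)c(F)c1)N1Cc2c(-c3ccc(F)cc3)cnn2CC1C1CC1` has not yet been measured in this assay. It differs from compound 1 in one place: 4-fluorophenyl in place of 4-(1,3-oxazol-5-yl)-2-oxopyrrolidin-1-yl on an aromatic carbon. Within the data shown here, the groups that leave and enter are the only change; the shared core and the carbamoyl-linked trifluorophenyl part are kept.

Among the measured compounds shown here, no measured pair in this set differs in a single place, so no measured step can be cited. Given that the leaving group carries three hydrogen-bond acceptors and the entering 4-fluorophenyl carries none, the author expects the step of a 2.8-fold lower number from compound 1 to compound 4 (0.44 log units; beyond the scatter) to run toward less compound tolerated, a moderate step rather than a large one. For compound 4 the author estimates 50000 nM, with a range from 12000 nM to 200000 nM.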

Compound 4, half-maximal cytotoxic concentration: 38500 nM
Beside the measured number, compound 4's estimate is 1.3-fold (0.11 log units) above it; measured number inside the range.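

In this assay, putting 4-fluorophenyl in place of 4-(1,3-oxazol-5-yl)-2-oxopyrrolidin-1-yl on this aromatic carbon brings a 3.6-fold lower number from compound 1 to compound 4 (0.56 log units; beyond the scatter). Going by these compounds alone, this is the first single-place step available here, and it shows that the group at this position can shift the tolerated concentration, though only modestly, even when a group with 3 hydrogen-bond acceptors gives way to one with 0 and the shared core and the carbamoyl-linked trifluorophenyl part stay in place. Compounds 2 and 3 add no number to set beside this step, since each of their values is only a limit: the limit of > 2000 nM in this assay, at which 2 of the 4 values shown sit.

The single step cannot show whether the shift follows from losing the oxazole, losing the pyrrolidinone ring, or gaining the fluorophenyl ring, and nothing shown gives a cause for it. It also leaves open how this assay would read with a small group at this carbon, such as an amine or a carboxylic acid, and whether an unsubstituted phenyl would read like the 4-fluorophenyl.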